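The source may report more compounds than this note shows. Statements on the series, on what has been measured and on what is new or still open speak of the compounds shown alone.

Compound 1 `N#Cc1ccc(O[C@H]2CN(S(=O)(=O)c3ccc(Cl)cc3Cl)C[C@@]2(O)CO)cc1F`: 54 L/kg
Compound 2 `N#Cc1ccc(O[C@H]2CN(S(=O)(=O)c3ccc(Cl)cn3)C[C@@]2(O)CO)cc1F`: 12 L/kg

In an ADME assay on the whole organism (Rattus norvegicus, strain Sprague-Dawley) for pharmacokinetics, read by LC-MS, with a stated time of 30 min (a higher number here means that more of the compound sits outside the plasma, a lower number that more of the compound stays in the plasma), compound 2 holds the lowest of the two numbers, at 12 L/kg. Within the data shown here, its only measured neighbour is compound 1, and the gap between them lies beyond the usual scatter. The next compound, compound 3 `N#Cc1ccc(O[C@H]2CN(S(=O)(=O)c3ccc(Cl)cc3)C[C@@]2(O)CO)cc1F`, has not yet been measured. It carries 4-chlorophenyl in place of 5-chloropyridin-2-yl on a sulfonyl sulfur.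

Among the measured compounds shown here, one measured step bears on this change: a 4.5-fold lower number from compound 1 to compound 2 (0.65 log units; beyond the scatter). There, 5-chloropyridin-2-yl replaced 2,4-dichlorophenyl at the same place. The new change is not simply that step run backwards, but it does restore a ring of carbon only, as in compound 1 at 54 L/kg. For the measured compounds named here, a rise in this assay is therefore expected, though probably a smaller one than the measured step, with only one step to guide it. The expected change is a 2.5-fold higher number from compound 2 to compound 3 (0.40 log units; beyond the scatter). For compound 3 the estimated value is 30 L/kg, with an expected range of 13 L/kg to 70 L/kg.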

Compound 3, volume of distribution at steady state: 170 L/kg
Compound 3: the middle estimate sits 5.7-fold (0.75 log units) below what was measured; the whole stated range lies below it.
By their numbers in this assay, from the lowest: compound 2; then compound 1; then compound 3.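

In this assay, the step at this sulfonyl sulfur is a 14-fold higher number from compound 2 to compound 3 (1.15 log units; beyond the scatter) when 4-chlorophenyl replaces 5-chloropyridin-2-yl. The two groups have the same number of heavy atoms and differ in that one ring atom is carbon rather than nitrogen, so this small exchange comes with a large step, larger than any other step among these compounds. The change of hydrogen in place of chloro on an aromatic carbon gives a 3.1-fold higher number from compound 1 to compound 3 (0.50 log units; beyond the scatter), which shows that a carbon-only ring does not fix the number at one level and that the chlorine count on that ring matters too, while nothing measured here offers a reason for either step.

As far as these compounds go, all three compounds share the same core and differ only in the aromatic group on the sulfonyl sulfur, so it remains open how far these two steps would hold on any other core. From the compounds shown here alone, it is also open where the number would fall with a methoxy group or an amine in place of the chlorine, on either the carbon-only ring or the ring with nitrogen.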